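A few compounds are considered here, and "the series" means these few. Any claim that something is new, unique, unknown or untested is made for them only; others in the source may bear on it.

Compound 1, `N#CC1=C(N)N(c2ccc(S(N)(=O)=O)cc2)C2=C(C(=O)CCC2)C1c1ccc(O)cc1`, is the reference point: in a functional assay on Ehrlich cells (Mus musculus) for antiproliferative activity, read by trypan blue exclusion, with a stated time of 2 h, tested at 10 ug/mL (a lower number here means a weaker effect, a higher number a stronger effect of the compound at the concentration tested), compound 1 gives 90%. Compound 2, `COc1ccc(C2C(C#N)=C(N)N(c3ccc(S(N)(=O)=O)cc3)C3=C2C(=O)CCC3)cc1`, differs from it only by a methyl in place of hydrogen on an oxygen on an aromatic ring, and in this assay compound 2 gives 30%. Among the measured compounds shown here, that single exchange produced a number 60 percentage points lower from compound 1 to compound 2 (beyond the scatter), so compound 2 stands lowest of the two measured values, with compound 1 as its only neighbour and well beyond the scatter from it. Compound 3, `N#CC1=C(N)N(c2ccc(S(N)(=O)=O)cc2)C2=C(C(=O)CCC2)C1c1ccc([N+](=O)[O-])cc1`, takes the next step: nitro in place of methoxy on an aromatic carbon. For the measured compounds named here, no measured step exchanges a methoxy for a nitro, but the one step that exists shows that altering the group at this place on the ring shifts the result by a large amount, so a sizeable move in either direction is plausible. For compound 3 the expected value is 55%, with a range from 20% to 90%. This means an expected step of a number 25 percentage points higher from compound 2 to compound 3 (beyond the scatter).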

Compound 3, a percentage reported as activity, at one concentration (the size of the read-out at that concentration, not a potency): 85%
Beside the measured number, compound 3's estimate is 30 percentage points below it, within the range that was stated.
By their numbers in this assay, from the lowest: compound 2; then compounds 3 and 1 (each within the scatter of the next).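

In this assay putting nitro in place of methoxy gives a number 55 percentage points higher from compound 2 to compound 3 (beyond the scatter) and so shows that a group at this place on the ring can bring back the high result. Putting nitro in place of hydroxy gives a number 5 percentage points lower from compound 1 to compound 3 (within the scatter) and so shows that two quite different groups can sit here with no difference beyond the usual spread of the assay. Among these three compounds, methoxy is the only group that stands apart, with the lowest result.

An amine, a carboxylic acid or a longer chain such as ethoxy at the same place would show whether the low result belongs to methoxy alone or extends to other groups. Why methoxy stands apart from hydroxy and nitro has no support in any measurement available here.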